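A weak growth inhibitor and one changed phenyl group

The compounds below may be only part of what the source reports. "The series", "measured", "known", "first", "only" and "open" are said of these compounds alone.

Compound 1 `COc1ccc(C(F)(F)F)cc1Nc1ncc(C(F)(F)F)c(N2Cc3cccc(N(C)S(C)(=O)=O)c3C2)n1`: > 30000 nM
Compound 2 `CN(c1cccc2c1CN(c1nc(Nc3cc(C(F)(F)F)cc(C(F)(F)F)c3)ncc1C(F)(F)F)C2)S(C)(=O)=O`: 10300 nM

In a functional assay on HepG2 cells (Homo sapiens) for antiproliferative activity, read by spectrophotometry, with a stated time of 2 days (a higher number here means a weaker inhibitor of growth, a lower number a stronger inhibitor of growth), compound 1 gives > 30000 nM, which is a limit of the assay and not a number. Its true value is therefore unknown. Compound 3 `CN(c1cccc2c1CN(c1nc(Nc3ccc(C(F)(F)F)cc3)ncc1C(F)(F)F)C2)S(C)(=O)=O` carries 4-(trifluoromethyl)phenyl in place of 2-methoxy-5-(trifluoromethyl)phenyl on a nitrogen on an aromatic ring. For the measured compounds named here, no measured pair shows this exact change, so any expectation is loose. Compound 2 shares the core and gives a real number, 10300 nM, so compound 3 is also expected to give a number, though a weak one. The expected change is a modest move toward stronger growth inhibition, an estimated at least 2.0-fold lower number from compound 1 to compound 3 (0.30 log units; that floor lies within the scatter). In this assay, the estimate for compound 3 is 15000 nM, with an expected range from 5000 nM to 40000 nM.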

Compound 3, concentration for 50% growth inhibition: > 30000 nM
Compound 3 ended at the assay's limit (the forecaster's own chance of this, stated with the estimate: 35%); middle value at least 2.0-fold (0.30 log units) away from the limit.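

For the compounds shown here, compound 1 and compound 3 both end at a limit of the assay rather than at a number, so no step between them can be read, because neither true value is known: the limit of > 30000 nM in this assay, at which 2 of the 3 values shown sit. The compounds shown leave open how strongly either compound inhibits growth, and whether exchanging the phenyl group changes that at all.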